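The compounds below may be only part of what the source reports. "The series", "measured", "known", "first", "only" and "open" are said of these compounds alone.

Compound 1 `Cc1ccccc1N1CCN(S(=O)(=O)CC23CCC(CC2NC(=O)[C@@H]2CCCNC2)C3(C)C)CC1` is measured in a functional assay (Pituitary gland cell) with Rattus norvegicus as the target (a higher number here means that more compound is needed for the effect, a lower number that less compound is needed), at 135 nM. Compound 2 `Cc1ccccc1N1CCN(S(=O)(=O)CC23CCC(CC2NC(=O)[C@H]2CCCNC2)C3(C)C)CC1` differs only in the drawn configuration of one ring stereocentre, and in this assay compound 2 reaches only the limit > 5000 nM, not a number. The step of an at least 37-fold higher number from compound 1 to compound 2 (1.56 log units; beyond the scatter) is therefore bounded by the limit of > 5000 nM in this assay, at which 1 of the 2 values shown sits, and rests on (the fact that one of compounds 1 and 2 is drawn with a defined configuration and the other without, at the place where they differ). For the measured compounds named here, compound 3 `Cc1ccccc1N1CCN(S(=O)(=O)CC23CCC(CC2NC(=O)CC(C)(C)N)C3(C)C)CC1` introduces a different change, (2-amino-2-methylpropyl in place of piperidin-3-yl on a carbonyl carbon), which removes the defined stereocentre altogether, and no measured step touches this kind of exchange. The only step shown, from compound 1 to compound 2, speaks to configuration rather than to the group itself, so its size cannot be carried over directly. Compound 3 is expected to sit between the two measured values, with the step of an at least 3.3-fold lower number from compound 2 to compound 3 (0.52 log units; beyond the scatter) understood as an estimate. Compound 3 is estimated at 1500 nM, in a range from 300 nM to 8000 nM.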

Compound 3, half-maximal effective concentration: > 10000 nM
Compound 3 gave a limit, no number (the forecaster's own chance of this, stated with the estimate: 35%); middle value at least 6.6-fold (0.82 log units) from the limit.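

In this assay, 2-amino-2-methylpropyl in place of piperidin-3-yl on a carbonyl carbon gives an at least 74-fold higher number from compound 1 to compound 3 (1.86 log units; beyond the scatter), so at this place the open chain does not keep the response seen with the ring of compound 1. Compound 3 stands at > 10000 nM, which is a limit of the assay and not a number. The earlier compounds shown here spoke only to the configuration of one ring stereocentre, whereas this result concerns the group itself, although the step from compound 2 to compound 3 cannot be read, both values being limits.

On these data alone, whether a pyrrolidin-3-yl or a 3-aminopropyl group on the same carbonyl carbon would give a measurable number in this assay stays open. Also open is how far the true value of compound 3 lies from what is printed, and the size of the step rests on this: the limit of > 10000 nM in this assay, at which 1 of the 3 values shown sits.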